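Methoxy step on the pendant ring, transferred to a second core

The source may hold more compounds than are shown below. What is called first, only, known or untested is meant among the compounds shown, and "the series" means these compounds.

Measured so far in a functional assay on Jurkat cells (Homo sapiens) for antiproliferative activity, read by MTT assay; on this read-out higher numbers stand for weaker inhibition and lower numbers for stronger inhibition:
compound 1, `COc1cccc(/C=C2\CCc3cc(OC)c(OC)cc3C2=O)c1`, gives 5000 nM
compound 2, `COc1cc(/C=C2\CCc3cc(OC)c(OC)cc3C2=O)cc(OC)c1`, gives 5000 nM
compound 3, `COc1cccc(/C=C2\Cc3cc(OC)c(OC)cc3C2=O)c1`, gives 12800 nM

Compound 2 carries methoxy in place of hydrogen on an aromatic carbon relative to compound 1; the step of no change at the digits printed from compound 1 to compound 2 (within the scatter). Compound 3 sits on a different core, and the difference between the two cores is not broken down here; compound 3 stands highest of the three numbers, beyond the scatter from both compound 1 and compound 2.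

Compound 4, `COc1cc(/C=C2\Cc3cc(OC)c(OC)cc3C2=O)cc(OC)c1`, is not yet measured. It carries methoxy in place of hydrogen on an aromatic carbon relative to compound 3, the same change, at the same kind of place, as compound 1 to compound 2. Because no change at the digits printed from compound 1 to compound 2 (within the scatter), the expected step of no change at the digits printed from compound 3 to compound 4 (within the scatter) is flat in this assay, resting on that one pair only. Compound 4 is estimated at 12800 nM, between 5000 nM and 32000 nM.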

Compound 4, half-maximal inhibitory concentration: 3000 nM
For compound 4 the middle estimate is 4.3-fold (0.63 log units) above the measured one, outside the stated range (below it).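

In this assay the added methoxy gives a 4.3-fold lower number from compound 3 to compound 4 (0.63 log units; beyond the scatter) on the core of compound 3. The same change does not carry across these two cores as a step of one size: the same change on two cores in this assay, no change at the digits printed (within the scatter) from compound 1 to compound 2 and a 4.3-fold lower number (0.63 log units; beyond the scatter) from compound 3 to compound 4, 4.3-fold (0.63 log units) apart, beyond the scatter of two such steps. This rests on a single pair per core, and it does not show how the step would run on any further core, nor which part of the difference between the cores sets the two steps apart.

The compounds shown leave open whether an amine, a hydroxyl or a fluorine at the same place would follow the methoxy step on either core. Also open, going by these compounds, is whether a longer chain, such as ethoxy, would separate the two cores in the same way.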